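A few compounds are considered here, and "the series" means these few. Any claim that something is new, unique, unknown or untested is made for them only; others in the source may bear on it.

Among the measured compounds shown here, in a functional assay on NB1 cells (Homo sapiens) for antiproliferative activity, with a stated time of 72 h (on this read-out lower numbers stand for stronger inhibition and higher numbers for weaker inhibition), compound 1 (`Cc1ccc(CNC(=O)CCN(Cc2ccc(C(=O)NO)cc2)C(=O)c2ccc(N(C)C)cc2)cc1`) gives 700 nM, the lower of the two numbers measured so far. Compound 2 (`Cc1ccc(NC(=O)CCN(Cc2ccc(C(=O)NO)cc2)C(=O)c2ccccc2)cc1`) gives 1480 nM, a gap beyond the usual scatter, which makes compound 1 the stronger of the pair. Compound 3 (`CN(C)c1ccc(C(=O)N(CCC(=O)NCc2ccccc2)Cc2ccc(C(=O)NO)cc2)cc1`) has not yet been measured. It departs from compound 1 by one change: hydrogen in place of methyl on an aromatic carbon. For the measured compounds named here, no measured pair shows this change. In this assay, no step beyond the scatter is expected. The estimated step runs a 1.1-fold higher number from compound 1 to compound 3 (0.06 log units; within the scatter). For compound 3 the expected value is 800 nM, with a range of 350 nM to 1800 nM.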

Compound 3, half-maximal inhibitory concentration: 1720 nM
The estimate for compound 3 lay 2.2-fold (0.33 log units) below the measured number, within the range that was stated.
By their numbers in this assay, from the lowest: compound 1; then compounds 2 and 3 (each within the scatter of the next).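

Among the compounds shown here, replacing the 4-methylbenzyl group with benzyl gives the first single-place comparison in this assay, and the step is a 2.5-fold higher number from compound 1 to compound 3 (0.39 log units; beyond the scatter). This shows that a single methyl, on an aromatic carbon para to a large group, makes a modest but real difference on this read-out, with the methyl-bearing compound 1 giving the lower number. Nothing available explains this difference.

Only methyl and hydrogen are compared at this position, so a methoxy group, a chlorine atom or an amine there remains an open case. From the compounds shown here alone, whether the step carries over to a compound without the dimethylamino group also stays open.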